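Replacing the methyl with 4-methoxyphenyl on a pyrazolopyridinone

The source may report more compounds than this note shows. Statements on the series, on what has been measured and on what is new or still open speak of the compounds shown alone.

Compound 1 `Cc1cc2c(c(N)nn2C)c(=O)[nH]1` and compound 2 `Cc1cc2nn(-c3ccccc3)c(N)c2c(=O)[nH]1` share a core that differs only in the group on the ring nitrogen. In an assay on isolated protein for inhibition of serine/threonine-protein kinase D2 (Homo sapiens), read by mobility shift assay, tested at 30 uM (on this read-out lower numbers stand for less inhibition and higher numbers for more inhibition at the one concentration tested (going by the name of the read-out)), compound 1 gives 5%, and compound 2 gives -1%; the two numbers lie within the usual scatter of each other, so neither shows inhibition beyond noise. Compound 3 `COc1ccc(-c2cc3nn(-c4ccccc4)c(N)c3c(=O)[nH]2)cc1` carries the change (4-methoxyphenyl in place of methyl on an aromatic carbon). Among the compounds with values here, no measured pair shows what this change does, so compound 3 is expected to move by a number 11 percentage points higher from compound 2 to compound 3 (beyond the scatter), a modest rise near the edge of the scatter. In this assay compound 3 is estimated at 10%, between -10% and 40%.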

Compound 3, a percentage reported as inhibition, at one concentration (the size of the read-out at that concentration, not a potency): 28%
For compound 3 the middle estimate is 18 percentage points below the measured one, within the range that was stated.
By their numbers in this assay, from the lowest: compounds 2 and 1 (each within the scatter of the next); then compound 3.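

Putting 4-methoxyphenyl in place of methyl on this aromatic carbon, next to the ring nitrogen, moves the result in this assay by a number 29 percentage points higher from compound 2 to compound 3 (beyond the scatter). This position therefore accepts a six-membered aromatic ring, and it gives inhibition beyond noise, which compound 1 and compound 2 did not show. Nothing available here accounts for the rise.

As far as these compounds go, it remains open whether the ring or its methoxy group matters more. Also open, from the compounds shown here alone, is what an unsubstituted phenyl, a carboxylic acid or an amine would give on the same carbon.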